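The compounds below may be only part of what the source reports. "The series", "measured", "known", "first", "only" and "open" are said of these compounds alone.

Going by the values given here, in a functional assay (blood) for inhibition, with Homo sapiens as the target (on this read-out higher numbers stand for weaker inhibition and lower numbers for stronger inhibition), three related compounds have numbers so far. Compound 1 `Cn1nnc(-c2cc(-c3ccccc3)c3ccc(OCc4cccc(C5(O)CCOCC5)c4)cc3c2)n1` gives 310 nM, compound 2 `N#Cc1cc(-c2ccoc2)c2ccc(OCc3cccc(C4(O)CCOCC4)c3)cc2c1` gives 10 nM, and compound 3 `OC1(c2cccc(COc3ccc4c(-c5ccoc5)cc(C5=NCCO5)cc4c3)c2)CCOCC1` gives 50 nM, the middle value of the three.

Compound 4 `O=C(c1ccccc1)c1cc(-c2ccoc2)c2ccc(OCc3cccc(C4(O)CCOCC4)c3)cc2c1` is still unmeasured. It differs from compound 3 in one place: a group of 8 heavy atoms (7 carbon, 1 oxygen; one six-membered aromatic ring of carbon only) in place of a group of 5 heavy atoms (3 carbon, 1 nitrogen, 1 oxygen; one five-membered non-aromatic ring with 2 hetero atoms), on an aromatic carbon. The benzoyl group sits on an aromatic carbon, meta to a furan-3-yl group.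

Among the compounds with values here, only one measured step changes this same place alone: a 5.0-fold higher number from compound 2 to compound 3 (0.70 log units; beyond the scatter). Within the data shown here, that modest step lies beyond the scatter, but a single step cannot establish a trend, and no measured compound carries benzoyl. Compound 1 differs from compound 3 in more than one place, so it gives no clean comparison.

A small move towards a higher number is therefore expected, no larger than that modest step, though the direction remains uncertain. The estimated step is a 1.8-fold higher number from compound 3 to compound 4 (0.26 log units; within the scatter). For compound 4, the expected value is 90 nM, with an estimated range of 25 nM to 320 nM.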

Compound 4, half-maximal inhibitory concentration: 200 nM
For compound 4 the middle estimate is 2.2-fold (0.35 log units) below the measured one; measured number inside the range.
By their numbers in this assay, from the lowest: compound 2; then compound 3; then compounds 4 and 1 (each within the scatter of the next).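

In this assay, benzoyl is the least favourable of the three groups compared at this position on the shared core, with a clear rise when it replaces the five-membered ring (a 4.0-fold higher number from compound 3 to compound 4 (0.60 log units; beyond the scatter)) and a larger one when it replaces cyano (a 20-fold higher number from compound 2 to compound 4 (1.30 log units; beyond the scatter)). Among these three compounds with furan-3-yl, the number now rises in step with the heavy-atom count of the group, from cyano through the five-membered ring to benzoyl, although three compounds cannot show that size is what matters. Nothing available here explains these differences.

Going by these compounds, it remains open whether an amine, a carboxylic acid or a simple amide at this position would fit the same order. It is also unclear whether the order would hold with phenyl in place of furan-3-yl.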